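The compounds below may be only part of what the source reports. "The series", "measured", "known", "first", "only" and "open" are said of these compounds alone.

Measured so far in a functional assay on HepG2 cells (Homo sapiens) for inhibition, read by MTT assay; a higher number here means a weaker inhibitor of growth, a lower number a stronger inhibitor of growth:
- compound 1 `COc1cc2oc(-c3cccc(NC(=O)c4ccc(Br)cc4)c3)cc(=O)c2c(OC)c1OC`: 8850 nM
- compound 2 `COc1cc2oc(-c3cccc(NC(=O)c4ccc([N+](=O)[O-])cc4)c3)cc(=O)c2c(OC)c1OC`: 18800 nM

Of these two, compound 2 has the higher number, 18800 nM, and so is the weaker inhibitor of growth in this assay. Compound 3 `COc1cc2oc(-c3cccc(NC(=O)c4ccc(C#N)cc4)c3)cc(=O)c2c(OC)c1OC` differs from compound 2 by a single change, cyano in place of nitro on an aromatic carbon, para to a large group.

Among the measured compounds shown here, only one measured step bears on this change, a 2.1-fold higher number from compound 1 to compound 2 (0.33 log units; beyond the scatter), with nitro in place of bromo at that same place. For the measured compounds named here, no measured compound carries cyano, so the guidance is indirect. Resting on a 2.1-fold higher number from compound 1 to compound 2 (0.33 log units; beyond the scatter), a modest step toward a lower number is expected, though one within the scatter would be no surprise. The expected change is a 1.4-fold lower number from compound 2 to compound 3 (0.16 log units; within the scatter). For compound 3 the estimated value is 13000 nM, with an expected range of 6000 nM to 28000 nM.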

Compound 3, concentration for 50% growth inhibition: 10200 nM
Estimate against measurement, compound 3: 1.3-fold (0.11 log units) above; the range from low to high includes it.
By their numbers in this assay, from the lowest: compounds 1, 3 and 2 (each within the scatter of the next, the first and the last beyond it).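

In this assay, among the compounds shown here, compound 3 gives the first reading of a nitrile on this aromatic carbon, para to a large group, and replacing nitro with cyano amounts to a 1.8-fold lower number from compound 2 to compound 3 (0.27 log units; within the scatter) and no more. For the compounds shown here, replacing bromo with cyano gives a 1.2-fold higher number from compound 1 to compound 3 (0.06 log units; within the scatter) and also stays small, so compound 3 cannot be told apart from either of the others, although those two remain separated by a 2.1-fold higher number from compound 1 to compound 2 (0.33 log units; beyond the scatter) as the only step here that clears the scatter. Nothing measured here explains these readings.

From the compounds shown here alone, whether the number moves further at this place remains open, since an amine, a carboxylic acid or a longer chain could be tried on the same carbon. Going by these compounds, it also remains open whether cyano, nitro and bromo would compare in the same way on another carbon of that ring.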